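Replacing thiophen-2-yl with 2-methylprop-1-en-1-yl in compound 2

The compounds below may be only part of what the source reports. "The series", "measured", "known", "first", "only" and "open" are said of these compounds alone.

Of the compounds shown here, three have been measured in a functional assay on CHO cells for activation of 5-hydroxytryptamine receptor 1D (Homo sapiens), read by GTPgammaS binding; on this read-out lower numbers stand for smaller maximal responses and higher numbers for larger maximal responses. Compound 1 `c1ccc(C2CCCCN2C2CCN(CCCc3c[nH]c4ccc(-n5cnnc5)cc34)CC2)cc1` gives 65%, compound 2 `CN(Cc1cccs1)C1CCN(CCCc2c[nH]c3ccc(-n4cnnc4)cc23)CC1` gives 81%, and compound 3 `CC(=O)Nc1ccc([C@H](C)NCC2CCN(CCCc3c[nH]c4ccc(-n5cnnc5)cc34)CC2)cc1` gives 99%. Compound 2 thus stands second highest of the three: compound 1 lies lower by a margin beyond the usual scatter, and compound 3 lies higher, again by a margin beyond the scatter. Among the measured compounds shown here, no two measured compounds differ in one place only, so no single-point step is available to guide an expectation.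

Compound 4 `CC(C)=CCN(C)C1CCN(CCCc2c[nH]c3ccc(-n4cnnc4)cc23)CC1` has not yet been measured. It differs from compound 2 in that (2-methylprop-1-en-1-yl in place of thiophen-2-yl on a saturated chain carbon bound to an amine nitrogen). The change is confined to the group on a saturated chain carbon bound to an amine nitrogen; the rest of compound 2 is kept. The closest reference remains compound 2 with 81%. Compound 4 is therefore expected to give about 80% in this assay, with a range from 60% to 98%. The expected step of a number 1 percentage points lower from compound 2 to compound 4 (within the scatter) is small and may well lie within the scatter, with no clear direction.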

Compound 4, largest response reached (reported as efficacy), in percent of the reference or control that the assay uses: 115%
Compound 4: the middle estimate sits 35 percentage points below what was measured, and the stated range ends below it.
By their numbers in this assay, from the lowest: compound 1; then compound 2; then compound 3; then compound 4.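

In this assay, among the compounds shown here, the group on a saturated chain carbon bound to an amine nitrogen proves to be a place where the read-out moves: a number 34 percentage points higher from compound 2 to compound 4 (beyond the scatter) is the only single-place step so far. The step also shows that a five-membered aromatic ring with a sulfur atom is not needed at this place for a large maximal response, since compound 4 carries no ring there, only an open chain with a double bond. No measurement at hand bears on what lies behind this step.

Still open, from the compounds shown here alone, is whether the double bond matters, which a saturated 3-methylbutyl group at this place would test, and whether a phenyl ring would behave like thiophen-2-yl. The compounds shown also leave open whether the change would carry over to the amine parts of compound 1 or compound 3.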